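Moving a Hydroxyl Group on Three Aryl Compounds

The compounds below may be only part of what the source reports. "The series", "measured", "known", "first", "only" and "open" are said of these compounds alone.

Compound 1 `Oc1cccc(-c2cc(-c3cccs3)cc(-c3cccc(O)c3)n2)c1` inhibits DNA topoisomerase 1 in an assay on isolated protein for inhibition of DNA topoisomerase 1 (Homo sapiens), with a stated time of 30 min, tested at 100 uM (a higher number here means a stronger effect of the compound at the concentration tested, a lower number a weaker effect), where compound 1 gives 91.7%. Compound 2 `Oc1ccc(-c2cc(-c3cccs3)cc(-c3cccc(O)c3)n2)cc1` differs by 4-hydroxyphenyl in place of 3-hydroxyphenyl on an aromatic carbon and gives 85.7%; that change made a number 6 percentage points lower from compound 1 to compound 2 (within the scatter). Compound 3 `Oc1ccc(-c2cc(-c3ccoc3)cc(-c3cccc(O)c3)n2)cc1` carries furan-3-yl in place of thiophen-2-yl and gives 37.4%, a fall described by a number 48.3 percentage points lower from compound 2 to compound 3 (beyond the scatter). Compound 4 `Oc1ccc(-c2cc(-c3ccoc3)cc(-c3ccc(O)cc3)n2)cc1` is not yet measured; it differs from compound 3 by 4-hydroxyphenyl in place of 3-hydroxyphenyl on an aromatic carbon. This is the same kind of change as from compound 1 to compound 2, though the surroundings differ: in compound 3 the place lies meta to a 4-hydroxyphenyl group and meta to a furan-3-yl group, whereas in compound 1 it lies meta to a 3-hydroxyphenyl group and meta to a thiophen-2-yl group. The difference between the cores of compound 1 and compound 3 is not broken down here. Because a number 6 percentage points lower from compound 1 to compound 2 (within the scatter) lay within the scatter, the step to compound 4 is expected to be small, about a number 4.4 percentage points lower from compound 3 to compound 4 (within the scatter). Compound 4 is therefore estimated at 33%, with a likely range from 15% to 52%.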

Compound 4, a percentage reported as inhibition, at one concentration (the size of the read-out at that concentration, not a potency): 74.9%
The estimate for compound 4 lay 41.9 percentage points below the measured number; the measured number lies above the stated range.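

On the furan-3-yl core, 4-hydroxyphenyl in place of 3-hydroxyphenyl gave a number 37.5 percentage points higher from compound 3 to compound 4 (beyond the scatter) in this assay, so the outcome seen on the thiophen-2-yl core did not carry over: the same change on two cores in this assay, a number 6 percentage points lower (within the scatter) from compound 1 to compound 2 and a number 37.5 percentage points higher (beyond the scatter) from compound 3 to compound 4, 43.5 percentage points apart, beyond the scatter of two such steps. Across these two pairs, then, the effect of this change depends on the core and cannot simply be transferred from one to the other. The two cores differ both in the thiophen-2-yl or furan-3-yl group and in the other hydroxyphenyl group, and the pairs do not show which of these differences matters.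

The compounds shown leave open how a thiophen-2-yl compound bearing two 4-hydroxyphenyl groups would behave. They also leave open whether a methoxy group or an amine could stand in place of either hydroxyl.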